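The source may report more compounds than this note shows. Statements on the series, on what has been measured and on what is new or still open speak of the compounds shown alone.

Compound 1 `CCOC(=O)c1sc(-c2cccc(NC(=O)c3ccco3)c2)nc1Nc1ccc(N2CCN(C)CC2)cc1` and compound 2 `CN1CCN(c2ccc(Nc3nc(-c4cccc(NC(=O)c5ccccc5F)c4)sc3C(N)=O)cc2)CC1` were both tested in a functional assay on Raji cells (Homo sapiens) for antiproliferative activity, read by CCK-8 assay, with a stated time of 72 h, tested at 40 uM; a lower number here means less inhibition, a higher number more inhibition at the concentration tested (going by the name of the read-out). Compound 1 gives 87.6%, and compound 2 gives 97.3%, the higher of the two numbers, though the gap to compound 1 lies within the scatter of the method. Compound 3 `CN1CCN(c2ccc(Nc3nc(-c4cccc(NC(=O)c5ccco5)c4)sc3C(N)=O)cc2)CC1` has not yet been measured there. It differs from compound 2 in one place: furan-2-yl in place of 2-fluorophenyl on a carbonyl carbon. Among the compounds with values here, no pair of measured compounds shows this change alone, so the step from compound 2 to compound 3 is expected to be small, a number 4.3 percentage points lower from compound 2 to compound 3 (within the scatter), in no direction beyond the scatter. Compound 3 is therefore estimated at 93%, between 80% and 99%.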

Compound 3, a percentage reported as inhibition, at one concentration (the size of the read-out at that concentration, not a potency): 84.3%
Compound 3: middle estimate off by 8.7 percentage points, on the high side; the measured number falls inside the stated range.
By their numbers in this assay, from the lowest: compounds 3, 1 and 2 (each within the scatter of the next, the first and the last beyond it).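

In this assay, within the data shown here, the position on the carbonyl carbon of the anilide amide responds to this change: furan-2-yl in place of 2-fluorophenyl gives a number 13 percentage points lower from compound 2 to compound 3 (beyond the scatter) and is the only step here that clears the scatter. With furan-2-yl held constant, amino in place of ethoxy on a carbonyl carbon gives a number 3.3 percentage points lower from compound 1 to compound 3 (within the scatter) and so cannot be told from scatter. Nothing available explains the step. Open, going by these compounds, is whether an unsubstituted phenyl on that carbonyl would behave like 2-fluorophenyl or like furan-2-yl. Also open, on these data alone, is how a carboxylic acid would compare with ethoxy and amino.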